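Lengthening a guanidine acyl chain in a melanoma cell growth assay

The source may report more compounds than this note shows. Statements on the series, on what has been measured and on what is new or still open speak of the compounds shown alone.

Measured compounds and their values:
compound 1 `CC(C)=CCC/C(C)=C/CC/C(C)=C/C(=O)NC(=N)N`, 9200 nM
compound 2 `CC(C)=CCC/C(C)=C/CC/C(C)=C/C(=O)NC(=N)NC(=O)C=C(C)C`, 7500 nM
compound 3 `CC(C)=CCC/C(C)=C/C(=O)NC(=N)NC(=O)C=C(C)C`, 25000 nM

In a functional assay on B16-F10 cells (Mus musculus) for inhibition, read by MTT assay, with a stated time of 72 h (on this read-out lower numbers stand for stronger inhibition of growth and higher numbers for weaker inhibition of growth), compound 2 gives the lowest of the three numbers, though compound 1 sits within the scatter of it, so the two cannot be told apart; compound 3 is the only one clearly set off. Compound 4 `CC(C)=CCC/C(C)=C/CC/C(C)=C/C(=O)NC(=N)NC(=O)/C=C(\C)CC/C=C(\C)CCC=C(C)C` is compound 2 with one change: 3,7-dimethylocta-2,6-dien-1-yl in place of hydrogen on a saturated chain carbon bound to a double-bonded chain carbon.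

Going by the values given here, two measured steps bear on this change. The step of a 1.2-fold lower number from compound 1 to compound 2 (0.09 log units; within the scatter) shows that adding the small acyl group itself made no difference beyond the scatter. The step of a 3.3-fold higher number from compound 2 to compound 3 (0.52 log units; beyond the scatter) shows that removing a chain piece from the other side of the core gave a modest loss. Adding a longer chain on the acyl side may thus give a modest gain, but nothing measured speaks to a chain of this length there, so the expected step from compound 2 to compound 4 is a 1.5-fold lower number from compound 2 to compound 4 (0.18 log units; within the scatter), with no large change expected. Compound 4 is therefore estimated at 5000 nM, within a range from 2000 nM to 12000 nM.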

Compound 4, concentration for 50% growth inhibition: 5700 nM
Compound 4: the middle estimate sits 1.1-fold (0.06 log units) below what was measured, and the stated range covers the measured number.
By their numbers in this assay, from the lowest: compounds 4, 2 and 1 (each within the scatter of the next); then compound 3.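

In this assay, the step of a 1.3-fold lower number from compound 2 to compound 4 (0.12 log units; within the scatter) shows that a much larger group can sit on a saturated chain carbon bound to a double-bonded chain carbon without a loss of growth inhibition beyond the scatter. Until now, this side of the molecule carried only the small acyl group of compound 2, so the tolerance of 3,7-dimethylocta-2,6-dien-1-yl is new information. Nothing here explains why this added chain leaves the number within the scatter.

On these data alone, it remains open whether a chain longer than 3,7-dimethylocta-2,6-dien-1-yl would still be accepted at this place. As far as these compounds go, it is equally open whether a chain ending in an amine or a carboxylic acid would give a number clearly set apart from that of compound 2.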